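From methylamino to 1H-imidazol-1-yl: estimating a clearance

The source may report more compounds than this note shows. Statements on the series, on what has been measured and on what is new or still open speak of the compounds shown alone.

In an ADME assay on microsomes from liver (Rattus norvegicus) for metabolic stability (a lower number here means slower removal, a higher number faster removal of the compound), compound 1 `CNc1nc(NC)nc(NC2(C#N)CCCCC2)n1` gives 210 mL/min/kg. Going by the values given here, the only other measured compound, compound 2 `CNc1nc(NC2(C#N)CCCCCC2)nc(-n2cncn2)n1`, gives 276 mL/min/kg. These two numbers lie within the usual scatter of repeated measurements, so they cannot be told apart and compound 1 cannot be ranked against compound 2.

The next compound, compound 3 `CNc1nc(NC2(C#N)CCCCC2)nc(-n2ccnc2)n1`, keeps the rest of compound 1 and changes one group: 1H-imidazol-1-yl in place of methylamino on an aromatic carbon. The new group is a five-membered aromatic ring, and it stands meta to the remaining methylamino group.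

Among the compounds with values here, no measured pair shows this exchange on its own, so the data give no direct guide to its size. Within the data shown here, the only anchor is how close together the two known numbers sit, with compound 1 at 210 mL/min/kg and compound 2 at 276 mL/min/kg. The expected result is a 1.1-fold higher number from compound 1 to compound 3 (0.06 log units; within the scatter), a step not expected to go beyond the scatter in either direction. In this assay, compound 3 is estimated at 240 mL/min/kg, with an expected range of 130 mL/min/kg to 420 mL/min/kg.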

Compound 3, clearance: 52 mL/min/kg
For compound 3 the middle estimate is 4.6-fold (0.66 log units) above the measured one; measured number below the stated range.
By their numbers in this assay, from the lowest: compound 3; then compounds 1 and 2 (each within the scatter of the next).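

Among the compounds shown, this is the first single change that moves the number beyond the scatter: in this assay the exchange on the aromatic carbon between two ring nitrogen atoms gives a 4.0-fold lower number from compound 1 to compound 3 (0.61 log units; beyond the scatter). So this position is not indifferent to what stands on it, and replacing methylamino with 1H-imidazol-1-yl goes with slower removal in this pair, while the methylamino group on the other side of the ring and the rest of compound 1 stay the same. The exchange alters several things at once, adding a five-membered aromatic ring and changing the count of hydrogen-bond donors and acceptors, and nothing measured here says which of these differences matters.

The compounds shown leave open whether the second nitrogen of the new ring matters, which a pyrazol-1-yl or a plain phenyl group on the same carbon could help to test. They also leave open whether the same exchange would have a similar effect at the remaining methylamino group, or on a core carrying a different ring in place of the cyclohexane.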